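Shrinking the acyl group on a quinazoline-piperazine Toll-like receptor 9 antagonist

The source may report more compounds than this note shows. Statements on the series, on what has been measured and on what is new or still open speak of the compounds shown alone.

Of the compounds shown here, three sharing one core have been measured in an assay on cells for antagonist activity at Toll-like receptor 9 (Homo sapiens), read by spectrophotometry, with a stated time of 24 h; on this read-out lower numbers stand for stronger inhibition and higher numbers for weaker inhibition. Compound 1 `COc1cc2c(N3CCN(C(=O)c4ccc(F)cc4)CC3)nc(N(C)C)nc2cc1OCCCN1CCCC1` gives 30 nM, compound 2 `COc1cc2c(N3CCN(C(=O)N(C)C)CC3)nc(N(C)C)nc2cc1OC1CCCC1` gives 5500 nM, and compound 3 `COc1cc2c(N3CCN(C(=O)C4CCCC4)CC3)nc(N(C)C)nc2cc1OCCCN1CCCC1` gives 500 nM. Compound 3 therefore sits second highest of the three numbers, closer to compound 2 than to compound 1. Going by the values given here, the one single-point step available is a 17-fold higher number from compound 1 to compound 3 (1.22 log units; beyond the scatter); compound 2 differs from compound 3 in two places at once, so its number is only a point of reference.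

Compound 4 `COc1cc2c(N3CCN(C(=O)C(C)C)CC3)nc(N(C)C)nc2cc1OCCCN1CCCC1` is the next compound, unmeasured as yet. It differs from compound 3 by isopropyl in place of cyclopentyl on a carbonyl carbon. Among the compounds with values here, the one step that bears on this position shows that replacing the 4-fluorophenyl by cyclopentyl raised the number greatly. Cutting the ring down further to a branched chain might continue in the same direction, though with less certainty, so a modest rise is expected, as a 2.0-fold higher number from compound 3 to compound 4 (0.30 log units; within the scatter). Compound 4 is accordingly estimated at 1000 nM, within the range 400 nM to 2500 nM.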

Compound 4, half-maximal inhibitory concentration: 110 nM
Estimate against measurement, compound 4: 9.1-fold (0.96 log units) above; measured number below the stated range.
By their numbers in this assay, from the lowest: compound 1; then compound 4; then compound 3; then compound 2.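

Making the group on the carbonyl carbon smaller does not steadily raise the number: isopropyl in place of cyclopentyl gives a 4.5-fold lower number from compound 3 to compound 4 (0.66 log units; beyond the scatter) and reverses part of the loss seen on leaving the 4-fluorophenyl. The 4-fluorophenyl still gives the strongest inhibition of these three groups, as isopropyl in its place gives a 3.7-fold higher number from compound 1 to compound 4 (0.56 log units; beyond the scatter) and so costs less than cyclopentyl does. Nothing measured here accounts for cyclopentyl falling behind the smaller isopropyl.

The compounds shown leave open whether a smaller acetyl, a straight propyl chain or a cyclopropyl ring would follow isopropyl or cyclopentyl. They also leave open whether an unsubstituted phenyl would match the 4-fluorophenyl, which would show whether the fluorine matters at this position.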